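Side-chain terminus variations on a cytotoxicity series

The source may report more compounds than this note shows. Statements on the series, on what has been measured and on what is new or still open speak of the compounds shown alone.

Measured compounds:
- compound 1, `CN(C(=O)C[C@@H](N)CCCN=C(N)N)C1CN=C(NC(N)=O)NC1=O`: 250 nM
- compound 2, `C/N=C(/N)NCCC[C@H](N)CC(=O)N(C)C1CN=C(NC(N)=O)NC1=O`: 5500 nM
- compound 3, `CN(C(=O)C[C@@H](N)CCCN)C1CN=C(NC(N)=O)NC1=O`: 25000 nM

In a functional assay on J774 cells (Mus musculus) for cytotoxicity (a higher number here means that more compound is needed for the effect, a lower number that less compound is needed), compound 3 gives the highest number of the three, set apart from compound 2 by a 4.5-fold higher number from compound 2 to compound 3 (0.66 log units; beyond the scatter) and from compound 1 by a 100-fold higher number from compound 1 to compound 3 (2.00 log units; beyond the scatter). Compound 4 is `CN(C(=O)C[C@@H](N)CCCCN)C1CN=C(NC(N)=O)NC1=O`; its change from compound 3 is aminomethyl in place of amino on a saturated chain carbon, four bonds along the chain from an amine nitrogen. For the measured compounds named here, no measured step swaps one of these groups for the other; the two steps into compound 3 replace the terminal amine with a larger group and are large, which shows the terminus matters, but says nothing about lengthening the chain by one carbon. The step of a 1.7-fold lower number from compound 3 to compound 4 (0.22 log units; within the scatter) is therefore expected to stay near the scatter, leaning slightly toward a lower number. Compound 4 is estimated at 15000 nM, with a range from 5000 nM to 50000 nM.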

Compound 4, half-maximal effective concentration: 6000 nM
Compound 4: the middle estimate sits 2.5-fold (0.40 log units) above what was measured; low and high end bracket the measured number.
By their numbers in this assay, from the lowest: compound 1; then compounds 2 and 4 (each within the scatter of the next); then compound 3.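

In this assay, aminomethyl in place of amino on this saturated chain carbon is a step beyond the scatter by itself (a 4.2-fold lower number from compound 3 to compound 4 (0.62 log units; beyond the scatter)), so the terminal amine does not need replacing for the number to move. The aminomethyl compound still stands well apart from the terminus of compound 1 (a 24-fold higher number from compound 1 to compound 4 (1.38 log units; beyond the scatter)), yet shows no separation from the terminus of compound 2 (a 1.1-fold higher number from compound 2 to compound 4 (0.04 log units; within the scatter)). The compounds shown leave open whether a longer chain carrying the amine, or a carboxylic acid in its place, would shift the number further. Nothing at hand bears on what lies behind these steps.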